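The compounds below may be only part of what the source reports. "The series", "measured", "known", "first", "only" and "open" are said of these compounds alone.

Of the compounds shown here, three sharing one core have been measured in a physicochemical assay for solubility, in phosphate buffer, at pH 7.4; a higher number here means a more soluble compound, a lower number a less soluble compound. Compound 1 `CC(=O)N[C@@H]1CCC[C@H](C(=O)Nc2cc(-c3cnn4ccccc34)c(Cl)cn2)C1` gives 45000 nM, compound 2 `CC(=O)N[C@@H]1CCC[C@H](C(=O)Nc2cc(-c3cnc4n3CCCC4)c(Cl)cn2)C1` gives 600000 nM, and compound 3 `CC(=O)N[C@@H]1CCC[C@H](C(=O)Nc2cc(-c3cnn4c3CCC4)c(Cl)cn2)C1` gives 160000 nM, which places compound 3 second highest of the three. The change to compound 4 `CC(=O)N[C@@H]1CCC[C@H](C(=O)Nc2cc(-c3cnn4c3NCCC4)c(Cl)cn2)C1` is a group of 9 heavy atoms (6 carbon, 3 nitrogen; one five-membered aromatic ring with 2 hetero atoms, one six-membered non-aromatic ring with 2 hetero atoms) in place of a group of 8 heavy atoms (6 carbon, 2 nitrogen; one five-membered non-aromatic ring with 1 hetero atom, one five-membered aromatic ring with 2 hetero atoms), on an aromatic carbon, opposite the ring nitrogen.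

The closest measured comparison involves the only six-membered non-aromatic ring tested so far: a 3.8-fold lower number from compound 2 to compound 3 (0.57 log units; beyond the scatter), a modest step. The two other steps also bear on the change, namely a 13-fold higher number from compound 1 to compound 2 (1.12 log units; beyond the scatter), which is large, and a 3.6-fold higher number from compound 1 to compound 3 (0.55 log units; beyond the scatter), which is modest. For the measured compounds named here, no measured compound carries a six-membered non-aromatic ring with 2 hetero atoms, so the expectation remains loose. In this assay, a modest rise is expected, with the estimated step being a 2.2-fold higher number from compound 3 to compound 4 (0.34 log units; beyond the scatter). The estimate for compound 4 is 350000 nM, with an expected range from 110000 nM to 900000 nM.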

Compound 4, solubility: 860000 nM
Beside the measured number, compound 4's estimate is 2.5-fold (0.39 log units) below it, within the range that was stated.
By their numbers in this assay, from the lowest: compound 1; then compound 3; then compounds 2 and 4 (each within the scatter of the next).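

In this assay the move to a six-membered non-aromatic ring with 2 hetero atoms, on the aromatic carbon opposite the ring nitrogen, gives a 5.4-fold higher number from compound 3 to compound 4 (0.73 log units; beyond the scatter) and, against the six-membered aromatic ring of the core of compound 1, a 19-fold higher number from compound 1 to compound 4 (1.28 log units; beyond the scatter) as a large step. Compared with the group carrying only 1 hetero atom in its six-membered non-aromatic ring, it gives a 1.4-fold higher number from compound 2 to compound 4 (0.16 log units; within the scatter) so those two groups cannot be separated here, and the two compounds with such a ring stand together above compounds 1 and 3. No measurement shown offers any explanation for these differences. From the compounds shown here alone, what the hydrogen-bond donor of the new group contributes remains open. A methyl group on that ring nitrogen, or an oxygen atom in its place, would bear on this question.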